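The source may hold more compounds than are shown below. What is called first, only, known or untested is meant among the compounds shown, and "the series" means these compounds.

Compound 1 `COc1ccc2cc([C@H](C)c3nnc(SCc4ccc(Cl)cc4)n3-c3ccc(F)cc3)ccc2c1`: > 400000 nM (a limit)
Compound 2 `COc1ccc2cc([C@H](C)c3nnc(SCc4c(C)cc(C)cc4C)n3-c3cccc(Cl)c3)ccc2c1`: <= 400000 nM (a limit)

Both entries come from a functional assay on LNCaP cells (Homo sapiens) for cytotoxicity, read by MTT assay; a lower number here means a stronger inhibitor, a higher number a weaker inhibitor. As far as these compounds go, compound 1 stands at > 400000 nM, which is a limit and not a number, so its exact strength is unknown. Compound 3 `COc1ccc2cc([C@H](C)c3nnc(SCc4ccc(C)cc4)n3-c3ccc(F)cc3)ccc2c1` keeps the core of compound 1 and differs in one place: methyl in place of chloro on an aromatic carbon. Here, methyl replaces chloro on an aromatic carbon, turning 4-chlorobenzyl into 4-methylbenzyl. Among the compounds with values here, no measured pair shows this change, so no step beyond the scatter is expected. The expected change is a number no higher from compound 1 to compound 3 (the limit leaves the size open). Compound 3 is estimated at 400000 nM. The expected range runs from 150000 nM to 900000 nM.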

Compound 3, half-maximal inhibitory concentration: <= 400000 nM
Compound 3: a limit, no number; the forecaster's own chance of this, stated with the estimate: 65%; the middle value lies on the limit itself.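

In this assay compound 3 gives <= 400000 nM, which is a limit and not a number. Exchanging 4-chlorobenzyl for 4-methylbenzyl gives a number no higher from compound 1 to compound 3 (the limit leaves the size open), the only step shown at this position, and it offers a direction but no size. Most values shown are limits: the limit of <= 400000 nM in this assay, at which 2 of the 3 values shown sit.

As far as these compounds go, how much the methyl itself contributes remains open. An amine or a carboxylic acid in place of the methyl could show whether this position can give a value that is a true number in this assay.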